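Pyridin-2-yl for cyclohexyl on the piperazine-bearing amide

The source may report more compounds than this note shows. Statements on the series, on what has been measured and on what is new or still open speak of the compounds shown alone.

Compound 1 `O=C(CN1CCN(C2CCCCC2)CC1)Nc1nc2c(s1)CCCC2` was tested in an assay on isolated protein for inhibition of long-chain fatty acid transport protein 1 (Mus musculus), read by scintillation counting, with a stated time of 20 min; a higher number here means a weaker inhibitor, a lower number a stronger inhibitor. In this assay compound 1 gives > 10000 nM, which is a limit of the assay and not a number. Compound 2 `O=C(CN1CCN(c2ccc(F)cc2)CC1)Nc1nc2c(s1)CCC2` also reaches only a limit in this assay, at > 10000 nM. For the measured compounds named here, compound 3 `O=C(CN1CCN(c2ccc(F)cn2)CC1)Nc1nc2c(o1)CCCC2` is the one member of the set with a measured number, and in this assay compound 3 gives 1700 nM. Compound 1 therefore stands at the limit of > 10000 nM in this assay, at which 2 of the 3 values shown sit, so its position relative to the others cannot be ranked beyond that.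

Compound 4 `O=C(CN1CCN(c2ccccn2)CC1)Nc1nc2c(s1)CCCC2` has not yet been measured. It differs from compound 1 in one place: pyridin-2-yl in place of cyclohexyl on an amine nitrogen in a ring. Going by the values given here, no pair of measured compounds differing in a single place is available, so the size of this step has to be expected rather than read off. Among the compounds with values here, compound 3, the only compound that carries an aromatic nitrogen-containing ring on the amine nitrogen and the only one with a number at 1700 nM, hints that an aromatic ring there can bring the value inside the measurable window. On that basis compound 4 is expected to show a modest gain, with the step from compound 1 to compound 4 estimated as an at least 1.6-fold lower number from compound 1 to compound 4 (0.22 log units; that floor lies within the scatter). Compound 4 is estimated at 6000 nM, within a range from 1500 nM to 20000 nM.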

Compound 4, half-maximal inhibitory concentration: 4900 nM
For compound 4 the middle estimate is 1.2-fold (0.09 log units) above the measured one; the measured number falls inside the stated range.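

Compound 4 gives 4900 nM in this assay, so on the core of compound 1 this position can carry a group that brings the value inside the measurable range. For the compounds shown here, replacing cyclohexyl with pyridin-2-yl, two groups of equal heavy-atom count, gives an at least 2.0-fold lower number from compound 1 to compound 4 (0.30 log units; that floor lies within the scatter), the first step in this set that can be read between compounds differing in one place. That step is only a floor and its full size stays unknown, as its starting point is a limit of the assay and not a number: the limit of > 10000 nM in this assay, at which 2 of the 4 values shown sit.

The compounds shown leave open whether the step depends on the nitrogen of the pyridin-2-yl ring or on the aromatic ring alone, a question that a plain phenyl group at this place on the same core would address. Compound 3 differs from compound 4 in more than one place, so the separate contributions of its fluoro substituent and its core also remain unresolved.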